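Styryl piperidines: methoxy for acetyl on the aryl ring

This account rests on a few compounds, and the source may have more. Where it says the series, first, only, none or still open, it means among the compounds named here.

Three compounds of this series carry values. In a functional assay on OVCAR-3 cells (Homo sapiens) for inhibition, read by MTT assay, with a stated time of 24 h (a lower number here means a stronger inhibitor, a higher number a weaker inhibitor), compound 1 `CN1CCCC[C@H]1/C=C/c1ccc(O)cc1` gives 1.94 ug/mL, compound 2 `Cc1cccc(C)c1/C=C/[C@@H]1CCCCN1` gives 6.27 ug/mL and compound 3 `CC(=O)c1ccc(/C=C/[C@@H]2CCCCN2)cc1` gives 2.18 ug/mL. Compound 3 stands second highest of the three; its value and that of compound 1 lie within the scatter of each other, while compound 2 sits beyond the scatter above it. Compound 4 `COc1ccc(/C=C/[C@@H]2CCCCN2)cc1` is not yet measured. It differs from compound 3 in one place: methoxy in place of acetyl on an aromatic carbon. Going by the values given here, no step between measured compounds bears on this change; the expectation is a small shift upward, at most near the edge of the scatter, so the step expected from compound 3 to compound 4 in this assay is a 1.4-fold higher number from compound 3 to compound 4 (0.14 log units; within the scatter). Compound 4 is estimated at 3 ug/mL, within 1.2 ug/mL to 7.5 ug/mL.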

Compound 4, half-maximal inhibitory concentration: 3.31 ug/mL
The estimate for compound 4 lay 1.1-fold (0.04 log units) below the measured number; the measured number falls inside the stated range.
By their numbers in this assay, from the lowest: compounds 1, 3, 4 and 2 (each within the scatter of the next, the first and the last beyond it).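

In this assay, going by these compounds alone, methoxy in place of acetyl on an aromatic carbon, para to a group of 8 heavy atoms, gives the only one-place step (a 1.5-fold higher number from compound 3 to compound 4 (0.18 log units; within the scatter)), and the exchange stays within the scatter. Both groups count one hydrogen-bond acceptor and no donor, and only acetyl has a double bond outside aromatic rings. Nothing measured here explains the step.

From the compounds shown here alone, whether an amine or a carboxylic acid on this aromatic carbon would stay within the scatter remains open. So does the effect of a longer chain in place of methoxy.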